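The source may report more compounds than this note shows. Statements on the series, on what has been measured and on what is new or still open speak of the compounds shown alone.

Working notes on the indole thiourea series.

Compound 1 `S=C(Nc1ccccc1)Nc1ccc2[nH]ccc2c1` is the unsubstituted phenyl member. In an ADME assay on cells for inhibition of Amine oxidase [flavin-containing] A (Homo sapiens), read by spectrophotometry (a lower number here means a stronger inhibitor, a higher number a weaker inhibitor), compound 1 gives > 30000 nM, which is a limit of the assay and not a measured number, and it sits at the limit of > 30000 nM in this assay, at which 1 of the 2 values shown sits. Compound 2 `Oc1cccc(NC(=S)Nc2ccc3[nH]ccc3c2)c1`, the phenol analogue, is the other member with a result in this assay, where compound 2 is recorded as "not active" (no number reported) with no number given. Among the measured compounds shown here, neither result places compound 1 anywhere other than at the weak end of what this assay reports, and there is no resolved step between the two measured compounds to calibrate a substituent change.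

Compound 3 `OCc1ccc(NC(=S)Nc2ccc3[nH]ccc3c2)cc1` is not yet measured. It differs from compound 1 by hydroxymethyl in place of hydrogen on an aromatic carbon. Given that compound 1 gives only a limit in this assay, and that compound 2 is likewise without a number, the step from compound 1 to compound 3 is expected to be none beyond the scatter, with a step that the limit leaves unreadable from compound 1 to compound 3 as the working expectation. Compound 3 is therefore estimated at 40000 nM in this assay, within a range from 15000 nM to 150000 nM, and most likely it too will return only a limit.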

Compound 3, half-maximal inhibitory concentration: "not active" (no number reported)
For compound 3 the study gives words and no number; there is nothing to compare the estimate with.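

Among the compounds shown here, compound 3, like compound 2, carries words and no number in this assay, so no step from compound 1 to compound 3 can be read. Compound 1 stands only at a limit of the assay: the limit of > 30000 nM in this assay, at which 1 of the 3 values shown sits.

The compounds shown leave open whether any member of the series inhibits the enzyme measurably, and what hydroxymethyl in place of hydrogen does to potency.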